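Thiophene for fluorophenyl on two related cores

This account rests on a few compounds, and the source may have more. Where it says the series, first, only, none or still open, it means among the compounds named here.

Compound 1 `C=C1CC[C@@H]2[C@](C)(CO)[C@H](O)CC[C@@]2(C)[C@@H]1CC(Sc1ccc(F)cc1)C1=CCOC1=O`: 16000 nM
Compound 2 `C=C1CC[C@@H]2[C@](C)(CO)[C@H](O)CC[C@@]2(C)[C@@H]1CC(Sc1cccs1)C1=CCOC1=O`: 15000 nM
Compound 3 `C=C1CC[C@@H]2[C@](C)(CO)[C@H](O)CC[C@@]2(C)[C@@H]1C/C=C1/C(=O)OC[C@H]1OC(=O)CCCSc1ccc(F)cc1`: 12000 nM

In a functional assay on PC-3 cells (Homo sapiens) for inhibition, read by MTT assay, with a stated time of 48 h (a lower number here means a stronger inhibitor, a higher number a weaker inhibitor), compound 1 gives 16000 nM. Compound 2 carries thiophen-2-yl in place of 4-fluorophenyl on a sulfur and gives 15000 nM, so the step of a 1.1-fold lower number from compound 1 to compound 2 (0.03 log units; within the scatter). Compound 3 is built on a different core; how the two cores differ is not broken down here, and compound 3 gives 12000 nM in this assay. Compound 4 `C=C1CC[C@@H]2[C@](C)(CO)[C@H](O)CC[C@@]2(C)[C@@H]1C/C=C1/C(=O)OC[C@H]1OC(=O)CCCSc1cccs1` is not yet measured; it differs from compound 3 by thiophen-2-yl in place of 4-fluorophenyl on a sulfur, the same change as from compound 1 to compound 2. Because the step of a 1.1-fold lower number from compound 1 to compound 2 (0.03 log units; within the scatter), compound 4 is expected to sit near compound 3, with an expected step of a 1.1-fold lower number from compound 3 to compound 4 (0.04 log units; within the scatter). The estimate for compound 4 in this assay is 11000 nM, expected between 6000 nM and 22000 nM.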

Compound 4, half-maximal inhibitory concentration: 16000 nM
Beside the measured number, compound 4's estimate is 1.5-fold (0.16 log units) below it, and the stated range covers the measured number.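

In this assay, thiophen-2-yl in place of 4-fluorophenyl on the sulfur gives a 1.3-fold higher number from compound 3 to compound 4 (0.12 log units; within the scatter), and the two cores do not separate on this change: the same change on two cores in this assay, a 1.1-fold lower number (0.03 log units; within the scatter) from compound 1 to compound 2 and a 1.3-fold higher number (0.12 log units; within the scatter) from compound 3 to compound 4, 1.4-fold (0.15 log units) apart, within the scatter of two such steps. The change therefore carries from the core of compound 1 to the core of compound 3 in the narrow sense that both steps stay within the scatter. This does not show that a step large enough to read would carry over, since neither pair gives one, and it says nothing beyond this one assay. The compounds shown leave open what an amine or a carboxylic acid on the sulfur chain would do. They also leave open whether a longer chain would keep the two cores in step.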